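A few compounds are considered here, and "the series" means these few. Any claim that something is new, unique, unknown or untested is made for them only; others in the source may bear on it.

Measured so far:
- compound 1, `c1ccc(-c2ccncc2)c(OCC2=NCCN2)c1`: in a functional assay for activation of Alpha-1A adrenergic receptor (Homo sapiens), read by calcium flux (a higher number here means that more compound is needed for the effect, a lower number that less compound is needed), compound 1 gives < 100000 nM, which is a limit of the assay and not a number.
- compound 2, `c1ccc(-c2ccsc2)c(OCC2=NCCN2)c1`: in this assay compound 2 gives 0.251 nM.
- compound 3, `c1ccc(-c2nccs2)c(OCC2=NCCN2)c1`: in this assay compound 3 gives 2.51 nM.

Among the two numbers shown, compound 3 has the highest, so it needs the most compound of those read as numbers; the only other number, that of compound 2, is lower by a 10-fold higher number from compound 2 to compound 3 (1.00 log units; beyond the scatter). Compound 4, `Cc1ccc(-c2ccccc2OCC2=NCCN2)s1`, has not yet been measured. It differs from compound 3 in one place: 5-methylthiophen-2-yl in place of 1,3-thiazol-2-yl on an aromatic carbon. Among the compounds with values here, the one measured step that bears on this is the exchange of thiophen-3-yl for 1,3-thiazol-2-yl, which gave a 10-fold higher number from compound 2 to compound 3 (1.00 log units; beyond the scatter). Compound 4 returns to a five-membered ring with a single sulfur, now carrying a methyl and joined through a different ring carbon, so a lower number than compound 3 is expected in this assay, likely approaching that of compound 2. For compound 4 a change of a 5.0-fold lower number from compound 3 to compound 4 (0.70 log units; beyond the scatter) is therefore estimated, giving an expected value of 0.5 nM within the range 0.1 nM to 3 nM.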

Compound 4, half-maximal effective concentration: 25.1 nM
Beside the measured number, compound 4's estimate is 50-fold (1.70 log units) below it; the measured number lies above the stated range.
By their numbers in this assay, from the lowest: compound 2; then compound 3; then compound 4.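

In this assay, a five-membered ring with a single sulfur does not by itself keep the number low at this position: the 5-methylthiophen-2-yl group gives a 100-fold higher number from compound 2 to compound 4 (2.00 log units; beyond the scatter), and a 10-fold higher number from compound 3 to compound 4 (1.00 log units; beyond the scatter). The count of hetero atoms in the ring therefore does not order these compounds, since compound 2 and compound 4 each have one and hold the lowest and highest numbers, while compound 3, with two, falls in the middle. The step from compound 1 to compound 4 cannot be read, since compound 1 carries a limit and not a number: the limit of < 100000 nM in this assay, at which 1 of the 4 values shown sits.

Going by these compounds, compound 4 differs from compound 2 both by its methyl and by its joining ring carbon, and which of these goes with the higher number stays open. An unsubstituted thiophen-2-yl would separate the two, while a methoxy or an amine in place of the methyl would show whether other groups on that ring behave alike.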